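Lengthening an Alkoxy Chain and Its Lipophilicity

The compounds below may be only part of what the source reports. "The series", "measured", "known", "first", "only" and "open" are said of these compounds alone.

Compound 1 `COc1ccc2[nH]c(-c3ccccc3)c(C3=C(Br)C(=O)NC3=O)c2c1`, compound 2 `CCOc1ccc2[nH]c(-c3ccccc3)c(C3=C(Br)C(=O)NC3=O)c2c1` and compound 3 `CCCCOc1ccc2[nH]c(-c3ccccc3)c(C3=C(Br)C(=O)NC3=O)c2c1` share one core and differ only in the chain on the ring oxygen. In a physicochemical assay for lipophilicity (a lower number here means a more polar compound, a higher number a more lipophilic compound), compound 1 gives 2.48, compound 2 gives 2.77 and compound 3 gives 3.42. The change methyl in place of hydrogen on a saturated chain carbon bound to an oxygen on an aromatic ring made the step of a number 0.29 log units higher from compound 1 to compound 2 (within the scatter). Compound 4 `CCCCCOc1ccc2[nH]c(-c3ccccc3)c(C3=C(Br)C(=O)NC3=O)c2c1` is not yet measured; it arises from compound 3 by methyl in place of hydrogen on a saturated chain carbon, four bonds along the chain from an oxygen on an aromatic ring, the same kind of change, though here the place is four bonds along the chain from the oxygen on the aromatic ring, not bound to it. The cores of compound 1 and compound 3 differ by propyl in place of hydrogen on a saturated chain carbon bound to an oxygen on an aromatic ring. Because the step of a number 0.65 log units higher from compound 2 to compound 3 (beyond the scatter) spans two added carbons, a single added carbon is expected to give a number 0.43 log units higher from compound 3 to compound 4 (beyond the scatter). Compound 4 is therefore expected to sit at 3.85, within 3.55 to 4.2.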

Compound 4, partition coefficient: 3.75
Compound 4: the middle estimate sits 0.10 log units above what was measured; measured number inside the range.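

In this assay, methyl in place of hydrogen four bonds along the chain gave a number 0.33 log units higher from compound 3 to compound 4 (beyond the scatter), whereas the same kind of change on the shortest chain gave a number 0.29 log units higher from compound 1 to compound 2 (within the scatter), so one case clears the scatter and the other does not. Across larger differences in the chain, the picture is a number 0.98 log units higher from compound 2 to compound 4 (beyond the scatter) and a number 1.27 log units higher from compound 1 to compound 4 (beyond the scatter), which fits a rise with chain length in these four compounds, apart from the step from compound 1 to compound 2, which stays within the scatter. These steps do not show that the change would give a similar step on a different core, and nothing available explains their size.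

On these data alone, whether the rise continues with a longer chain remains open. So does the effect of a chain carrying an amine or a carboxylic acid.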